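Carbonyl substituent exchange on compound 3: carbamate to amide

This account rests on a few compounds, and the source may have more. Where it says the series, first, only, none or still open, it means among the compounds named here.

Measured so far in a functional assay on isolated protein for agonist activity at Glucose-dependent insulinotropic receptor (Homo sapiens), read by HTRF and cAMP accumulation; a higher number here means that more compound is needed for the effect, a lower number that less compound is needed:
compound 1 `CC(C)(C)OC(=O)N1CCC(O[C@H]2CC[C@H](Oc3ccc(S(C)(=O)=O)c(F)c3)CC2)CC1`: 52 nM
compound 2 `CC(C)OC(=O)N1CCC(O[C@H]2CC[C@H](Oc3ccc(S(C)(=O)=O)nc3)CC2)CC1`: 13 nM
compound 3 `CC(C)OC(=O)N1CCC(O[C@H]2CC[C@H](Oc3cnc(S(C)(=O)=O)cn3)CC2)CC1`: 13.7 nM

In this assay compound 3 gives 13.7 nM, the second-highest of the three numbers. Compound 2 stands nearest, and the step of a 1.1-fold higher number from compound 2 to compound 3 (0.02 log units; within the scatter) lies within the scatter. For the measured compounds named here, compound 1 stands furthest, with a higher number that is beyond the scatter, but compound 1 and compound 3 differ in more than one place, so no single step connects them.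

Compound 4 `CS(=O)(=O)c1cnc(O[C@H]2CC[C@H](OC3CCN(C(=O)C4(C(F)(F)F)CC4)CC3)CC2)cn1` differs from compound 3 in one place: 1-(trifluoromethyl)cyclopropyl in place of isopropoxy on a carbonyl carbon. Going by the values given here, no measured step bears on this position. Among the compounds with values here, the single step, from compound 2 to compound 3, changes only the group on the oxygen on a saturated carbon, while the isopropoxycarbonyl is common to compound 2 and compound 3. Without a step on the carbonyl substituent, the expectation for compound 4 rests on compound 3 alone, and the step of a 1.5-fold higher number from compound 3 to compound 4 (0.16 log units; within the scatter) is expected to stay near or within the scatter. Compound 4 is therefore estimated at 20 nM (range 5 nM to 80 nM).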

Compound 4, half-maximal effective concentration: 107 nM
Compound 4: middle estimate off by 5.4-fold (0.73 log units), on the low side; the measured number lies above the stated range.
By their numbers in this assay, from the lowest: compounds 2 and 3 (each within the scatter of the next); then compound 1; then compound 4.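

For the compounds shown here, the carbonyl substituent is the first position where a single change moves the number beyond the scatter in this assay: a 7.8-fold higher number from compound 3 to compound 4 (0.89 log units; beyond the scatter), with 1-(trifluoromethyl)cyclopropyl in place of isopropoxy on a carbonyl carbon. Going by these compounds alone, the only earlier step, on the oxygen on a saturated carbon, stayed within the scatter at a 1.1-fold higher number from compound 2 to compound 3 (0.02 log units; within the scatter), so this position is the more sensitive of the two so far. Nothing available explains the rise.

Open, going by these compounds, is whether the rise follows from the loss of the isopropoxy oxygen or from the 1-(trifluoromethyl)cyclopropyl group itself, which a plain isopropyl or cyclopropyl on the same carbonyl carbon would separate. Also open, on these data alone, is whether the same exchange gives a similar step with the 6-(methylsulfonyl)pyridin-3-yl group of compound 2.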